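From oxan-2-yl to oxan-4-yl: a small structural swap

This account rests on a few compounds, and the source may have more. Where it says the series, first, only, none or still open, it means among the compounds named here.

Of the compounds shown here, three built on a shared core have been measured in an ADME assay on MDCKII-LE cells (Canis lupus familiaris) for permeability, read by transwell migration, in the apical to basolateral direction; on this read-out higher numbers stand for higher permeability and lower numbers for lower permeability. Here compound 1 `CC1(C)C[C@H](CN([C@H](CCC(F)(F)F)C(N)=O)S(=O)(=O)c2ccc(Cl)cc2)O1` gives 18.1 10^-6 cm/s, compound 2 `CC1(C)CO[C@H]1CN([C@H](CCC(F)(F)F)C(N)=O)S(=O)(=O)c1ccc(Cl)cc1` gives 26.4 10^-6 cm/s, and compound 3 `NC(=O)[C@@H](CCC(F)(F)F)N(C[C@H]1CCCCO1)S(=O)(=O)c1ccc(Cl)cc1` gives 13.4 10^-6 cm/s. Compound 3 lies within the usual scatter of both others, so these three numbers cannot be ranked with confidence.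

The next compound, compound 4 `NC(=O)[C@@H](CCC(F)(F)F)N(CC1CCOCC1)S(=O)(=O)c1ccc(Cl)cc1`, has the same atoms as compound 3, joined differently: oxan-4-yl in place of oxan-2-yl on a saturated chain carbon bound to a sulfonamide nitrogen. Put simply, oxan-4-yl stands in place of oxan-2-yl on a saturated chain carbon bound to a sulfonamide nitrogen.

Three measured steps change the group at this same place: a 1.5-fold higher number from compound 1 to compound 2 (0.16 log units; within the scatter), a 1.4-fold lower number from compound 1 to compound 3 (0.13 log units; within the scatter) and a 2.0-fold lower number from compound 2 to compound 3 (0.29 log units; within the scatter). All three remain within the scatter, including the swaps between oxan-2-yl and the two dimethyloxetan-2-yl groups. Among the compounds with values here, none of them exchanges oxan-2-yl for oxan-4-yl, so the evidence is indirect, and it covers only three compounds. On that basis, no change beyond the scatter is expected in this assay. The expected step is a 1.1-fold lower number from compound 3 to compound 4 (0.05 log units; within the scatter), which is no larger than the scatter. For compound 4 the estimated value is 12 10^-6 cm/s, with an expected range of 6.5 10^-6 cm/s to 22 10^-6 cm/s.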

Compound 4, apparent permeability: 26.3 10^-6 cm/s
Beside the measured number, compound 4's estimate is 2.2-fold (0.34 log units) below it, outside the stated range (above it).
By their numbers in this assay, from the lowest: compounds 3, 1, 4 and 2 (each within the scatter of the next).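

Moving the attachment point from oxan-2-yl to oxan-4-yl keeps the same atoms and gives a 2.0-fold higher number from compound 3 to compound 4 (0.29 log units; within the scatter) in this assay, so this rearrangement of the ring stays within the scatter. Set against the two dimethyloxetan-2-yl groups, oxan-4-yl also stays within the scatter, with a 1.0-fold lower number from compound 2 to compound 4 (0.00 log units; within the scatter) and a 1.5-fold higher number from compound 1 to compound 4 (0.16 log units; within the scatter), so none of the four groups at this place on a saturated chain carbon bound to a sulfonamide nitrogen stands apart from the other three. No supporting measurement is available to explain the small differences among these four compounds.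

On these data alone, all four groups are saturated rings containing an oxygen, so it remains open whether the numbers would stay in this same range with a different kind of group here, such as cyclohexyl with no ring oxygen, piperidin-4-yl with a ring amine, or a chain ending in a carboxylic acid. Only this one place varies across the four compounds, so they also leave open whether the same swap from oxan-2-yl to oxan-4-yl would give a similar step on a different core.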